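This account rests on a few compounds, and the source may have more. Where it says the series, first, only, none or still open, it means among the compounds named here.

Compound 1 `O=C1NC(=S)S/C1=C\C=C\c1ccccc1OCc1ccncc1`: 39.4%
Compound 2 `O=C1NC(=S)S/C1=C\C=C\c1ccccc1OCc1ccccc1`: 49.5%

In an assay on isolated protein for inhibition of protein tyrosine phosphatase type IVA 3 (Homo sapiens), tested at 5 ug/mL (a higher number here means more inhibition at the concentration tested (going by the name of the read-out), a lower number less inhibition), compound 2 gives 49.5%, the higher of the two numbers measured, while compound 1 gives 39.4%. Going by the values given here, the only step measured so far is a number 10.1 percentage points higher from compound 1 to compound 2 (beyond the scatter). Compound 3 `O=C1NC(=S)S/C1=C\C=C\c1ccccc1Cl` differs from compound 2 by chloro in place of benzyloxy on an aromatic carbon. Among the compounds with values here, that single measured step exchanged one ring for another inside the benzyloxy group, whereas here the whole benzyloxy group leaves and chloro enters, so no measured step matches this change closely. On that thin basis a modest downward step is expected, a number 14.5 percentage points lower from compound 2 to compound 3 (beyond the scatter). Compound 3 is therefore estimated at 35%, within 15% to 55%.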

Compound 3, a percentage reported as inhibition, at one concentration (the size of the read-out at that concentration, not a potency): 53.9%
Compound 3: the middle estimate sits 18.9 percentage points below what was measured; the range from low to high includes it.
By their numbers in this assay, from the lowest: compound 1; then compounds 2 and 3 (each within the scatter of the next).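

In this assay, replacing benzyloxy with chloro on this aromatic carbon gives a number 4.4 percentage points higher from compound 2 to compound 3 (within the scatter), so the extra six-membered aromatic ring and the oxygen of benzyloxy are not required for this level of inhibition. Replacing (pyridin-4-yl)methoxy with chloro gives a number 14.5 percentage points higher from compound 1 to compound 3 (beyond the scatter), so the single chlorine atom also outdoes that larger group here. No evidence is available to explain these numbers. Still open, going by these compounds, is how an amine, a carboxylic acid or a methoxy group would read on this carbon, and whether chloro would read the same elsewhere on the ring.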